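Ethyl on the amine nitrogen of compound 3

A few compounds are considered here, and "the series" means these few. Any claim that something is new, unique, unknown or untested is made for them only; others in the source may bear on it.

In a functional assay on A549 cells (Homo sapiens) for antiproliferative activity, read by MTT assay, with a stated time of 48 h (a lower number here means a stronger inhibitor, a higher number a weaker inhibitor), compound 1 (`CNCC(=O)Nc1cc(OC)ccc1C(=O)c1ccc(OC)c2c1C=CC(C)(C)O2`) gives 1370 nM and compound 2 (`CCNCC(=O)Nc1cc(OC)ccc1C(=O)c1ccc(OC)c2c1C=CC(C)(C)O2`) gives 2310 nM. On the same read-out, compound 3 (`C=C(c1cc(OC)c(OC)c(OC)c1)c1ccc(OC)cc1NC(=O)CN`) gives 40 nM, the lowest of the three numbers and beyond the scatter from both of the others.

Compound 4 (`C=C(c1cc(OC)c(OC)c(OC)c1)c1ccc(OC)cc1NC(=O)CNCC`) differs from compound 3 in one place: ethyl in place of hydrogen on an amine nitrogen. In words, this is ethyl in place of hydrogen on an amine nitrogen.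

For the measured compounds named here, only one measured step bears on this change: methyl in place of hydrogen on a saturated chain carbon bound to an amine nitrogen, a 1.7-fold higher number from compound 1 to compound 2 (0.23 log units; within the scatter). That step lies on a different core and at much higher numbers, and its starting amine nitrogen already carries a substituent, so it is a loose guide. Going by the values given here, no measured pair shows hydrogen being replaced on that nitrogen itself. A small move to a higher number is therefore expected, a 2.0-fold higher number from compound 3 to compound 4 (0.30 log units; within the scatter). For compound 4 the estimated value is 80 nM, with an expected range of 30 nM to 250 nM.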

Compound 4, half-maximal inhibitory concentration: 260 nM
For compound 4 the middle estimate is 3.3-fold (0.51 log units) below the measured one; measured number above the stated range.
By their numbers in this assay, from the lowest: compound 3; then compound 4; then compounds 1 and 2 (each within the scatter of the next).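

For the compounds shown here, on the core of compound 3, ethyl in place of hydrogen on an amine nitrogen gives a 6.5-fold higher number from compound 3 to compound 4 (0.81 log units; beyond the scatter) in this assay, the first single change whose step lies beyond the scatter. Going by these compounds alone, the amine nitrogen is therefore a position where the series responds to substitution, whereas the one other step, a 1.7-fold higher number from compound 1 to compound 2 (0.23 log units; within the scatter), on a different core, stays within the scatter and gave no such sign. Nothing at hand accounts for the size of this step.

On these data alone, whether the rise follows chain length remains open: methyl, propyl or a second ethyl on this nitrogen would show whether the number climbs gradually or hydrogen alone gives the low value. Also open, as far as these compounds go, is whether amino to ethylamino has the same size on the core of compound 1.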